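The source may hold more compounds than are shown below. What is called first, only, known or untested is meant among the compounds shown, and "the series" means these compounds.

Compound 1 `COc1ccc(Sc2ccc(NC3=NC(C)CN3)cc2)cc1` gives the lowest of the two numbers recorded in an assay (Rattus norvegicus) for binding affinity to prostacyclin receptor (Homo sapiens), read by radioligand binding (a lower number here means a stronger inhibitor, a higher number a weaker inhibitor), namely 63.1 nM. Within the data shown here, compound 2 `COc1ccc(Sc2ccc(NC3=NC(C)(C)CN3)cc2)cc1` gives 631 nM in this assay, and the only measured step, a 10-fold higher number from compound 1 to compound 2 (1.00 log units; beyond the scatter), arises from a methyl in place of hydrogen on a saturated ring carbon. Compound 3 `COc1ccc(Sc2ccc(-c3ncc[nH]3)cc2)cc1` is the unmeasured partner of compound 1; the change is a group of 5 heavy atoms (3 carbon, 2 nitrogen; one five-membered aromatic ring with 2 hetero atoms) in place of a group of 7 heavy atoms (4 carbon, 3 nitrogen; one five-membered non-aromatic ring with 2 hetero atoms), on an aromatic carbon. Among the measured compounds shown here, no measured step covers such a replacement of the whole ring, so the step to compound 2 bears on it only indirectly, in that even a small alteration of this ring cost a modest amount of affinity in this assay. The expected direction for compound 3 is therefore weaker binding, with a step of about a 10-fold higher number from compound 1 to compound 3 (1.00 log units; beyond the scatter). Compound 3 is accordingly estimated at 630 nM in this assay, within a range of 150 nM to 3000 nM.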

Compound 3, inhibition constant: < 10000 nM
Compound 3 was reported as a limit (the forecaster's own chance of this, stated with the estimate: 15%); the middle value lies beyond the limit too.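

No new step can be read between compound 1 and compound 3, because compound 3 is reported only as a limit and not as a number: the limit of < 10000 nM in this assay, at which 1 of the 3 values shown sits.

The compounds shown leave open how far 1H-imidazol-2-yl, in place of the five-membered non-aromatic ring of compound 1, shifts the number in this assay.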